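A few compounds are considered here, and "the series" means these few. Any claim that something is new, unique, unknown or untested is made for them only; others in the source may bear on it.

Working notes on the series.

Compound 1 `COc1ccc(-c2cnc3nc(N)nc(N4CCN(c5cc(Cl)cc(Cl)c5)CC4)c3n2)cc1OC` gives 3400 nM in a functional assay on cells (T-cell, Homo sapiens) for inhibition; on this read-out lower numbers stand for stronger inhibition and higher numbers for weaker inhibition. Compound 2 `CC(C)Oc1nc(N)nc2ncc(-c3ccc(F)c(F)c3)nc12` gives 10000 nM in this assay. Of the two numbers, compound 1 has the lower one, and the gap to compound 2 lies beyond the scatter of repeated runs, so compound 1 stands as the stronger of the pair as measured.

Compound 3 `COc1ccc(-c2cnc3nc(N)nc(N4CCN(C(=O)Nc5ccccc5)CC4)c3n2)cc1OC` is not yet measured. It differs from compound 1 in one place: phenylcarbamoyl in place of 3,5-dichlorophenyl on an amine nitrogen in a ring. Going by the values given here, no measured pair covers this kind of exchange, so the effect of the change is open. Given that compound 1 sits at 3400 nM, the step of a 1.2-fold higher number from compound 1 to compound 3 (0.07 log units; within the scatter) is expected to be small, with no clear direction beyond the scatter. Compound 3 is therefore estimated to give 4000 nM in this assay, with a range from 1000 nM to 15000 nM.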

Compound 3, half-maximal inhibitory concentration: 3.4 nM
Estimate against measurement, compound 3: 1200-fold (3.07 log units) above, and the stated range ends above it.
By their numbers in this assay, from the lowest: compound 3; then compound 1; then compound 2.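

Replacing 3,5-dichlorophenyl with phenylcarbamoyl on the amine nitrogen of the six-membered non-aromatic ring gives a 1000-fold lower number from compound 1 to compound 3 (3.00 log units; beyond the scatter) in this assay and shows that the group at this position can strongly change the read-out on the core of compound 1. The exchange keeps a six-membered aromatic ring of carbon only, removes both chlorine atoms, and brings in a carbonyl and an amide hydrogen, so this single pair cannot assign the step to any one of these differences. Nothing available explains the size of the step.

Still open, as far as these compounds go, is whether a benzoyl group, without the amide hydrogen, or a phenylcarbamoyl group carrying 3,5-dichloro substitution would retain the low number. Also open, from the compounds shown here alone, is how a methylcarbamoyl group, without the aromatic ring, would read out at this position.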